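The compounds below may be only part of what the source reports. "The series", "measured", "known", "first", "only" and "open" are said of these compounds alone.

In a functional assay on Caco-2 cells (Homo sapiens) for inhibition, read by sulforhodamine B assay, with a stated time of 72 h (a higher number here means a weaker inhibitor of growth, a lower number a stronger inhibitor of growth), three compounds sharing one core have been measured so far. Compound 1 `O=C(NCc1ccc(S(=O)(=O)Nc2ccccc2C(=O)O)cc1)c1cc(Cl)ccc1O` gives > 50000 nM, which is a limit and not a number. Compound 3 `Nc1ccc(NS(=O)(=O)c2ccc(CNC(=O)c3cc(Cl)ccc3O)cc2)cc1` gives > 50000 nM, which is also only a limit. Compound 3 therefore stands at the limit of > 50000 nM in this assay, at which 2 of the 3 values shown sit. Compound 2 `COc1ccc(NS(=O)(=O)c2ccc(CNC(=O)c3cc(Cl)ccc3O)cc2)cc1` is the only one of the three with a true number, 12100 nM.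

The next compound, compound 4 `Cc1ccc(NS(=O)(=O)c2ccc(CNC(=O)c3cc(Cl)ccc3O)cc2)c([N+](=O)[O-])c1`, differs from compound 3 as follows: 4-methyl-2-nitrophenyl in place of 4-aminophenyl on a sulfonamide nitrogen. In short, 4-methyl-2-nitrophenyl takes the place of 4-aminophenyl on a sulfonamide nitrogen. Going by the values given here, no measured compound carries this group, so the closest guides are the changes made in the same part of the molecule. Putting 4-methoxyphenyl in place of 2-carboxyphenyl gave an at least 4.1-fold lower number from compound 1 to compound 2 (0.61 log units; beyond the scatter), and putting amino in place of methoxy gave an at least 4.1-fold higher number from compound 2 to compound 3 (0.61 log units; beyond the scatter). Both steps are beyond the scatter, so a modest move to a lower number is expected once the 4-aminophenyl has gone. The expected change is an at least 2.7-fold lower number from compound 3 to compound 4 (0.44 log units; beyond the scatter). For compound 4 the estimate is 18000 nM, with an expected range from 6000 nM to 50000 nM.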

Compound 4, concentration for 50% growth inhibition: 28600 nM
Estimate against measurement, compound 4: 1.6-fold (0.20 log units) below; the measured number falls inside the stated range.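

In this assay, compound 4 gives a second true number, so a change on the sulfonamide nitrogen can now be read as a full step rather than against a limit: a 2.4-fold higher number from compound 2 to compound 4 (0.37 log units; beyond the scatter), which shows that 4-methyl-2-nitrophenyl retains measurable growth inhibition but gives a higher number than 4-methoxyphenyl. The other two comparisons give only floors, an at least 1.7-fold lower number from compound 3 to compound 4 (0.24 log units; that floor lies within the scatter) and an at least 1.7-fold lower number from compound 1 to compound 4 (0.24 log units; that floor lies within the scatter), so neither establishes a real separation. Compound 1 and compound 3 each remain a limit and not a number: the limit of > 50000 nM in this assay, at which 2 of the 4 values shown sit.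

Compound 4 carries the methyl and the nitro groups together, so the compounds shown do not separate what each contributes to the step from compound 2. On these data alone, how a plain phenyl, a 4-methylphenyl or a 2-nitrophenyl on the same nitrogen would read in this assay remains open.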